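Chloro for hydrogen on the pendant ring of compound 2

The compounds below may be only part of what the source reports. "The series", "measured", "known", "first", "only" and "open" are said of these compounds alone.

Three compounds share one core. In an in vitro ADME assay on microsomes from liver (Homo sapiens) for metabolic stability (on this read-out higher numbers stand for fast clearance and lower numbers for slow clearance), compound 1 `COc1ccccc1C1CCc2nc[nH]c2C1` gives "not determined" (no result reported) and compound 3 `COc1cccc(C2CCc3nc[nH]c3C2)c1` gives "not determined" (no result reported); neither has a number. Among the measured compounds shown here, compound 2 `c1ccc(C2CCc3nc[nH]c3C2)cc1` is the only member with a value: in this assay compound 2 gives 7 mL.min-1.g-1. For the measured compounds named here, it therefore stands alone as the sole reference point of the set, with no step between measured compounds available.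

Compound 4 `Clc1ccccc1C1CCc2nc[nH]c2C1` differs from compound 2 in one place: chloro in place of hydrogen on an aromatic carbon. Going by the values given here, no measured pair gives the size of such a change here. The expectation for compound 4 is a step of a 1.6-fold higher number from compound 2 to compound 4 (0.20 log units; within the scatter) in this assay, upward, at the edge of the usual scatter. Compound 4 is thus estimated at 11 mL.min-1.g-1, within a range of 4 mL.min-1.g-1 to 28 mL.min-1.g-1.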

Compound 4, intrinsic clearance in microsomes: 10 mL.min-1.g-1
Compound 4: middle estimate off by 1.1-fold (0.04 log units), on the high side; the measured number falls inside the stated range.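

In this assay, among the compounds shown here, chloro on an aromatic carbon, ortho to a group of 9 heavy atoms, gives a 1.4-fold higher number from compound 2 to compound 4 (0.15 log units; within the scatter) and this is the first step the series can read. At this position, the exchange of hydrogen for chloro therefore stays within the scatter, a reading that rests on this single pair. No measured property bears on the step, so it has no stated cause.

Steps to compound 1 and compound 3 cannot be read. From the compounds shown here alone, whether an amine or a carboxylic acid on the same aromatic carbon would also stay within the scatter of compound 2 remains open.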